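Chain stereocentre epimer in a small antiproliferative series

The source may hold more compounds than are shown below. What is called first, only, known or untested is meant among the compounds shown, and "the series" means these compounds.

Measured in a functional assay on NCI-H460 cells (Homo sapiens) for antiproliferative activity, with a stated time of 72 h; on this read-out lower numbers stand for stronger inhibition and higher numbers for weaker inhibition:
- compound 1 `C=CC[C@H]1C[C@]2([C@H](C)Cc3ccc(OC)c(OC)c3)OCOC2=CC1=O`: 320 nM
- compound 2 `C=CC[C@H]1C[C@]2([C@@H](C)Cc3ccc(OC)cc3)OCOC2=CC1=O`: 90 nM

Of these two numbers, compound 2 has the lowest at 90 nM, and the gap up to compound 1 lies beyond the scatter. Next in this assay is compound 3 `C=CC[C@H]1C[C@]2([C@H](C)Cc3ccc(OC)cc3)OCOC2=CC1=O`, the partner of compound 2 at one stereocentre: the two compounds have the same atoms and bonds and differ only in configuration as drawn: 1 of 3 stereo elements differ; a stereocentre at a saturated chain carbon is drawn S in compound 2 and R in compound 3. Nothing leaves and nothing enters; a stereocentre at a saturated chain carbon is drawn S in compound 2 and R in compound 3.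

Within the data shown here, no measured pair isolates this change, so its size remains open. With compound 2 at the low end at 90 nM, a rise towards weaker inhibition is expected rather than a further fall, probably only a little beyond the scatter. The expected move is a 2.2-fold higher number from compound 2 to compound 3 (0.35 log units; beyond the scatter). For compound 3 the estimated value is 200 nM, with an expected range of 70 nM to 700 nM.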

Compound 3, half-maximal inhibitory concentration: 120 nM
The estimate for compound 3 lay 1.7-fold (0.22 log units) above the measured number, and the stated range covers the measured number.
By their numbers in this assay, from the lowest: compounds 2 and 3 (each within the scatter of the next); then compound 1.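

In this assay, the chain stereocentre can now be read on its own, because nothing else separates this pair: the fact that compounds 2 and 3 differ only in the configuration as drawn. The result is a 1.3-fold higher number from compound 2 to compound 3 (0.12 log units; within the scatter), so with this substitution on the aromatic ring, the two configurations drawn at this carbon cannot be told apart in this read-out. Hydrogen in place of methoxy on an aromatic carbon, by contrast, does register, as a 2.7-fold lower number from compound 1 to compound 3 (0.43 log units; beyond the scatter).

On these data alone, it remains open whether the chain stereocentre is equally silent when the extra methoxy is present, since compound 1 appears here in only one configuration at that carbon. Also open, as far as these compounds go, is how a hydroxyl, an ethoxy group or a fluorine on that aromatic carbon would compare with methoxy and hydrogen.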